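The source may report more compounds than this note shows. Statements on the series, on what has been measured and on what is new or still open speak of the compounds shown alone.

Among the measured compounds shown here, compound 1 `COc1ccc(C(=O)/C=C/c2cc(-c3cc(OC)c(OC)c(OC)c3)n[nH]2)cc1OC` is the only member of the series with a number in a functional assay on NCI-H322M cells (Homo sapiens) for inhibition, read by sulforhodamine B assay, with a stated time of 48 h; on this read-out lower numbers stand for stronger inhibition of growth and higher numbers for weaker inhibition of growth: compound 1 gives 2900 nM. Compound 2 `COc1cc(-c2cc(/C=C/C(=O)c3ccc(F)c(F)c3)[nH]n2)cc(OC)c1OC` returns only a limit, > 100000 nM, which is the limit of > 100000 nM in this assay, at which 1 of the 2 values shown sits. For the measured compounds named here, the one measured step, an at least 34-fold higher number from compound 1 to compound 2 (1.53 log units; beyond the scatter), shows the ring on the carbonyl carbon is sensitive to change. Compound 3 `COc1cc(C(=O)/C=C/c2cc(-c3cc(OC)c(OC)c(OC)c3)n[nH]2)cc(OC)c1OC` differs from compound 1 by methoxy in place of hydrogen on an aromatic carbon. That step bears on the same ring but is a smaller change than the difluoro swap, so only a small shift, if any, is expected: compound 3 is estimated at 2500 nM, range 800 nM to 8000 nM, meaning an expected step of a 1.2-fold lower number from compound 1 to compound 3 (0.06 log units; within the scatter).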

Compound 3, concentration for total growth inhibition: 4850 nM
Beside the measured number, compound 3's estimate is 1.9-fold (0.29 log units) below it; the measured number falls inside the stated range.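

In this assay a methoxy in place of hydrogen on the ring on the carbonyl carbon gives a 1.7-fold higher number from compound 1 to compound 3 (0.22 log units; within the scatter) and so adds no readable change at this position. Sensitivity of this ring therefore does not extend to every change: added methoxy is tolerated here, while compound 2 alone remains a limit and not a number: the limit of > 100000 nM in this assay, at which 1 of the 3 values shown sits.

Still open, from the compounds shown here alone, is whether the loss in compound 2 follows from the fluorines entering or the methoxy groups leaving. Going by these compounds, how a hydroxy group or an amine would read at this position also remains open.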